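An untested change from compound 1 to compound 4

The source may report more compounds than this note shows. Statements on the series, on what has been measured and on what is new or still open speak of the compounds shown alone.

In a functional assay on DU-145 cells (Homo sapiens) for inhibition, read by trypan blue exclusion, with a stated time of 96 h (on this read-out lower numbers stand for stronger inhibition of growth and higher numbers for weaker inhibition of growth), compound 1 `COc1ccc(/C=C(/SCc2ccc(Cl)cc2)C(=O)c2ccc(Br)cc2)cc1O` gives 1000 nM, level with compound 2 `O=C(/C(=C\OCc1ccccc1)S(=O)(=O)c1ccccc1Cl)c1ccc(Cl)cc1` at 1000 nM and compound 3 `COc1ccc(/C=C(/SCc2ccc(F)cc2)C(=O)c2ccc(Br)cc2)cc1O` at 1000 nM. The next compound to be measured is compound 4 `COc1ccccc1/C=C(/SCc1ccc(Cl)cc1)C(=O)c1ccc(Br)cc1`, which carries 2-methoxyphenyl in place of 3-hydroxy-4-methoxyphenyl on a double-bonded chain carbon bound to a double-bonded chain carbon. Going by the values given here, the only measured step, no change at the digits printed from compound 1 to compound 3 (within the scatter), stays within the scatter, but it is a fluoro for chloro exchange on an aromatic carbon, elsewhere in the molecule. Among the compounds with values here, no measured step tests the new change directly, so the guide is weak. The expected step, no change at the digits printed from compound 1 to compound 4 (within the scatter), is none beyond the scatter. For compound 4 the estimated value is 1000 nM, with an expected range from 300 nM to 3500 nM.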

Compound 4, concentration for 50% growth inhibition: 1000 nM
The estimate for compound 4 equals the measured number at the digits printed; low and high end bracket the measured number.
By their numbers in this assay, from the lowest: compounds 1, 2, 3 and 4 (each within the scatter of the next).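

In this assay, putting 2-methoxyphenyl in place of 3-hydroxy-4-methoxyphenyl on a double-bonded chain carbon bound to a double-bonded chain carbon gives no change at the digits printed from compound 1 to compound 4 (within the scatter), the first step shown at this place. The read-out therefore holds level although the entering group has 0 hydrogen-bond donors and the leaving group has 1. No evidence bears on why the value holds.

From the compounds shown here alone, whether an amine or a carboxylic acid on this aromatic ring would shift the value stays open. So does whether any change at this place moves growth inhibition beyond the scatter.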